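Thiosemicarbazones of a terpenoid amine: aryl variation and growth inhibition

The source may hold more compounds than are shown below. What is called first, only, known or untested is meant among the compounds shown, and "the series" means these compounds.

Measured so far:
compound 1 `COc1ccc(/C=N\NC(=S)NC(C)(C)CCC[C@](C)(O)[C@@H]2CC=C(C)CC2)cc1` gives 34900 nM
compound 2 `CC1=CC[C@@H]([C@@](C)(O)CCCC(C)(C)NC(=S)N/N=C\c2cccc([N+](=O)[O-])c2)CC1` gives 560 nM
compound 3 `CC1=CC[C@@H]([C@@](C)(O)CCCC(C)(C)NC(=S)N/N=C\c2ccc([N+](=O)[O-])cc2)CC1` gives 9560 nM

All three compounds share the same core and differ only in the aryl group attached to the carbon with a double bond to nitrogen. In a functional assay on K562 cells (Homo sapiens) for cytotoxicity, read by sulforhodamine B assay (on this read-out higher numbers stand for weaker inhibition of growth and lower numbers for stronger inhibition of growth), compound 1 stands at the highest number of the three. Its nearest neighbour is compound 3, reached by a 3.7-fold lower number from compound 1 to compound 3 (0.56 log units; beyond the scatter); the furthest is compound 2, reached by a 62-fold lower number from compound 1 to compound 2 (1.79 log units; beyond the scatter). Between the two nitro isomers, a 17-fold higher number from compound 2 to compound 3 (1.23 log units; beyond the scatter) shows the aryl pattern matters a great deal in this assay.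

Compound 4 `CC1=CC[C@@H]([C@@](C)(O)CCCC(C)(C)NC(=S)N/N=C(/C)c2ccccc2)CC1` has not been measured. Relative to compound 1 the change is a group of 9 heavy atoms (8 carbon, 1 nitrogen; one six-membered aromatic ring of carbon only) in place of a group of 10 heavy atoms (8 carbon, 1 nitrogen, 1 oxygen; one six-membered aromatic ring of carbon only), on an amide-type nitrogen: the entering group carries no oxygen and has one fewer hydrogen-bond acceptor, and a methyl now sits on the carbon with a double bond to nitrogen. Among the measured compounds shown here, none of the measured steps alters that carbon or removes the aryl substituent entirely, so no step bears directly on this change; the measured steps only show that changes at the aryl end can be modest or large in either direction. With compound 1 as the starting point and the measured values spanning compound 2 to compound 1, a modest move is expected, of the size a 2.3-fold lower number from compound 1 to compound 4 (0.37 log units; beyond the scatter). Compound 4 is therefore estimated at 15000 nM, with a range from 3000 nM to 60000 nM.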

Compound 4, concentration for total growth inhibition: 70 nM
Estimate against measurement, compound 4: 210-fold (2.33 log units) above; measured number below the stated range.
By their numbers in this assay, from the lowest: compound 4; then compound 2; then compound 3; then compound 1.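

In this assay, among the compounds shown here, the change on the amide-type nitrogen gives a 500-fold lower number from compound 1 to compound 4 (2.70 log units; beyond the scatter) and is the largest step so far, larger than a 62-fold lower number from compound 1 to compound 2 (1.79 log units; beyond the scatter) at the same end of the molecule. The earlier compounds shown here all keep a hydrogen on the carbon with a double bond to nitrogen and carry a ring substituent, whereas compound 4 has a methyl on that carbon and an unsubstituted ring, and it has the lowest number of the four: compound 4 stands at 70 nM and compound 2 at 560 nM, so a nitro group is not required for a low number here. Nothing available accounts for the size of this step.

The step combines the entering methyl with the loss of the methoxy, and the compounds shown leave open how much of the drop belongs to each. Also open, going by these compounds, is whether a longer chain such as ethyl on that carbon, or a chlorine or an amine on the ring of compound 4, would keep the number this low.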